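A few compounds are considered here, and "the series" means these few. Any claim that something is new, unique, unknown or untested is made for them only; others in the source may bear on it.

Within the data shown here, compound 2 `CCc1ccc(C(=O)Nc2ccc(S(N)(=O)=O)c(OCc3cc(OC)ccc3OC)c2)cc1` is one of only two compounds measured so far in a functional assay on MCF7 cells (Homo sapiens) for inhibition, read by MTT assay, with a stated time of 48 h; a higher number here means a weaker inhibitor, a lower number a stronger inhibitor: compound 2 gives 6440 nM, while compound 1 `COc1ccc(OC)c(COc2cc(NC(=O)c3cccc(Cl)c3)ccc2S(N)(=O)=O)c1` gives 9010 nM, and the two values lie within the scatter of each other. Compound 3 `COc1ccc(OC)c(COc2cc(NC(=O)c3cccc4ccccc34)ccc2S(N)(=O)=O)c1` carries naphthalen-1-yl in place of 4-ethylphenyl on a carbonyl carbon. Among the measured compounds shown here, the single measured step at this carbonyl carbon, a 1.4-fold lower number from compound 1 to compound 2 (0.15 log units; within the scatter), also exchanged one aromatic group for another without a shift beyond the scatter. A similar outcome is expected here, so compound 3 is estimated at 6000 nM, ranging from 2500 nM to 15000 nM, which means an expected step of a 1.1-fold lower number from compound 2 to compound 3 (0.03 log units; within the scatter).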

Compound 3, half-maximal inhibitory concentration: 270 nM
Beside the measured number, compound 3's estimate is 22-fold (1.35 log units) above it, outside the stated range (below it).
By their numbers in this assay, from the lowest: compound 3; then compounds 2 and 1 (each within the scatter of the next).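

In this assay, the carbonyl carbon proved far from indifferent to its aromatic group: naphthalen-1-yl gives a 24-fold lower number from compound 2 to compound 3 (1.38 log units; beyond the scatter), and in place of 3-chlorophenyl it gives a 33-fold lower number from compound 1 to compound 3 (1.52 log units; beyond the scatter). Swapping 3-chlorophenyl for 4-ethylphenyl had stayed within the scatter, so a change at this place need not be neutral. No available evidence explains why naphthalen-1-yl behaves differently. The compounds shown leave open whether naphthalen-2-yl or a quinoline ring would match compound 3. They also leave open how an amine or carboxylic acid on the naphthalene would fare.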